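Adding a second chlorine to two related purine-like cores

The source may report more compounds than this note shows. Statements on the series, on what has been measured and on what is new or still open speak of the compounds shown alone.

Compound 1 `ClCc1ccc(Cn2cnc3c(Cl)ncnc32)cc1` and compound 2 `ClCc1cccc(Cn2cnc3ncnc(Cl)c32)c1` are built from the same atoms joined differently; how their two cores differ is not broken down here. Compound 3 `ClCc1ccc(Cn2cnc3c(Cl)nc(Cl)nc32)cc1` carries one more chlorine than compound 1, and compound 4 `ClCc1cccc(Cn2cnc3nc(Cl)nc(Cl)c32)c1` carries one more chlorine than compound 2.

In a functional assay on U-251 cells (Homo sapiens) for cytotoxicity, read by sulforhodamine B assay, with a stated time of 48 h (a higher number here means a weaker inhibitor of growth, a lower number a stronger inhibitor of growth), compound 1 gives 3010 nM, compound 2 gives 3980 nM, and compound 3 gives 3890 nM. All three numbers lie within the scatter of one another, so no order among them can be claimed.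

The change from compound 1 to compound 3 is chloro in place of hydrogen on an aromatic carbon. In this assay this gave a 1.3-fold higher number from compound 1 to compound 3 (0.11 log units; within the scatter).

The change from compound 2 to compound 4 is chloro in place of hydrogen on an aromatic carbon. Its place is described in the same words as the earlier change, so it is the same change made on the core of compound 2.

Because the earlier step of a 1.3-fold higher number from compound 1 to compound 3 (0.11 log units; within the scatter) did not move the number beyond the scatter, the expected step here is a 1.1-fold higher number from compound 2 to compound 4 (0.05 log units; within the scatter), also within the scatter. Since compound 2 gives 3980 nM, compound 4 is expected to give about 4500 nM in this assay, with a likely range from 2000 nM to 10000 nM. This expectation rests on one measured step only.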

Compound 4, concentration for total growth inhibition: 2690 nM
The estimate for compound 4 lay 1.7-fold (0.22 log units) above the measured number, within the range that was stated.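

In this assay, the same chloro in place of hydrogen, now on the other core, gave a 1.5-fold lower number from compound 2 to compound 4 (0.17 log units; within the scatter). Set beside the earlier step, this one cannot be told apart from it, even though one is printed as a higher number and the other as a lower number: the same change on two cores in this assay, a 1.3-fold higher number (0.11 log units; within the scatter) from compound 1 to compound 3 and a 1.5-fold lower number (0.17 log units; within the scatter) from compound 2 to compound 4, 1.9-fold (0.28 log units) apart, within the scatter of two such steps. This shows that, for these two pairs, the change carries from one core to the other in a simple sense: on both cores the added chlorine leaves the number within the scatter, so the apparent difference in direction should not be read as a real effect of the core, but two pairs in one cell line cannot show that the same would hold on other related cores or in other cells.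

The compounds shown leave open whether a different group on that same aromatic carbon, between two ring nitrogen atoms, such as an amine or a methoxy group, would move the number beyond the scatter. They also leave open whether any replacement of the chlorine already present on these cores, for instance by an amine, would matter more than adding this second one.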